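The source may hold more compounds than are shown below. What is called first, only, known or untested is meant among the compounds shown, and "the series" means these compounds.

Measured compounds in a functional assay on RAW264.7 cells (Mus musculus) for inhibition, read by immunoassay, with a stated time of 12 h, tested at 30 uM; on this read-out higher numbers stand for more inhibition at the one concentration tested (going by the name of the read-out) and lower numbers for less inhibition:
compound 1 `O=C1CC(c2ccccc2OCc2cccc(F)c2)Oc2ccccc21` gives 93.3%
compound 2 `CC(C)=CCOc1ccccc1C1CC(=O)c2ccccc2O1` gives 41.8%
compound 3 `COCOc1ccccc1C1CC(=O)c2ccccc2O1` gives 35.2%

Compound 3 stands lowest of the three numbers, though its nearest neighbour compound 2 lies within the scatter of it, so the two cannot be ordered; compound 1 lies far above both, as a number 58.1 percentage points lower from compound 1 to compound 3 (beyond the scatter) and a number 51.5 percentage points lower from compound 1 to compound 2 (beyond the scatter) show.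

Compound 4 `CCCCCOc1ccccc1C1CC(=O)c2ccccc2O1` differs from compound 3 by butyl in place of methoxy on a saturated chain carbon bound to an oxygen on an aromatic ring.

The step that bears on this is a number 6.6 percentage points lower from compound 2 to compound 3 (within the scatter), where one open-chain group replaced another on the same saturated chain carbon without a change beyond the scatter. Butyl is likewise an open chain, so no step beyond the scatter is expected in this assay; the large steps of a number 51.5 percentage points lower from compound 1 to compound 2 (beyond the scatter) and a number 58.1 percentage points lower from compound 1 to compound 3 (beyond the scatter) involve loss of the 3-fluorophenyl ring and do not apply here.

Compound 4 is therefore estimated at 42%, in the range 25% to 60%, an expected step of a number 6.8 percentage points higher from compound 3 to compound 4 (within the scatter).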

Compound 4, a percentage reported as inhibition, at one concentration (the size of the read-out at that concentration, not a potency): 41.3%
Compound 4: middle estimate off by 0.7 percentage points, on the high side; the measured number falls inside the stated range.
By their numbers in this assay, from the lowest: compounds 3, 4 and 2 (each within the scatter of the next); then compound 1.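

In this assay, butyl on a saturated chain carbon bound to an oxygen on an aromatic ring cannot be told apart from the other open chains, with a number 6.1 percentage points higher from compound 3 to compound 4 (within the scatter) and a number 0.5 percentage points lower from compound 2 to compound 4 (within the scatter) as the steps. An all-carbon saturated chain, carrying no oxygen, therefore reads like both methoxy and 2-methylprop-1-en-1-yl, so among these three groups neither the oxygen of methoxy nor the double bond of 2-methylprop-1-en-1-yl shows up in the read-out. With a number 52 percentage points lower from compound 1 to compound 4 (beyond the scatter) as a third large step away from 3-fluorophenyl, compound 1 alone stands apart among the compounds shown. No supporting data bear on the reason for this separation. Going by these compounds, whether plain phenyl or cyclohexyl would keep the number of compound 1 stays open. So does the reading of a longer chain such as octyl, or of a chain ending in an amine.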